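From 3-bromophenyl to 4-chlorophenyl: a small expected step

The source may hold more compounds than are shown below. What is called first, only, known or untested is meant among the compounds shown, and "the series" means these compounds.

Measured compounds:
Compound 1 `CC1(C)[C@H]2CC[C@]1(C)N(Cc1cn(-c3cccc(C#N)c3)nn1)C(=O)C2`: 40 nM
Compound 2 `Cc1ccccc1-n1cc(CN2C(=O)C[C@@H]3CC[C@@]2(C)C3(C)C)nn1`: 150 nM
Compound 3 `CC1(C)[C@H]2CC[C@]1(C)N(Cc1cn(-c3cccc(Br)c3)nn1)C(=O)C2`: 20 nM

In a functional assay on HepG2 cells (Homo sapiens) for inhibition, read by MTT assay, with a stated time of 24 h (on this read-out lower numbers stand for stronger inhibition and higher numbers for weaker inhibition), compound 3 gives 20 nM. Its nearest measured neighbour shows a 2.0-fold lower number from compound 1 to compound 3 (0.30 log units; within the scatter), while its furthest shows a 7.5-fold lower number from compound 2 to compound 3 (0.88 log units; beyond the scatter).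

The next structure is compound 4 `CC1(C)[C@H]2CC[C@]1(C)N(Cc1cn(-c3ccc(Cl)cc3)nn1)C(=O)C2`. The change is 4-chlorophenyl in place of 3-bromophenyl on an aromatic nitrogen, with 4-chlorophenyl in place of 3-bromophenyl on an aromatic nitrogen. Among the measured compounds shown here, no measured compound carries 4-chlorophenyl, so no step measures this change directly. The closest guidance comes from the steps that alter the group on that same nitrogen. Besides the two above, there is a 3.8-fold higher number from compound 1 to compound 2 (0.57 log units; beyond the scatter). These steps are modest or stay within the scatter, so only a small shift is expected here, more likely towards a higher number than a lower one. The estimated step is a 1.8-fold higher number from compound 3 to compound 4 (0.24 log units; within the scatter), and it is not expected to lie beyond the scatter. For compound 4 the expected value is 35 nM, with an estimated range of 10 nM to 120 nM.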

Compound 4, half-maximal inhibitory concentration: 90 nM
Estimate against measurement, compound 4: 2.6-fold (0.41 log units) below; low and high end bracket the measured number.
By their numbers in this assay, from the lowest: compounds 3 and 1 (each within the scatter of the next); then compounds 4 and 2 (each within the scatter of the next).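

In this assay, among the compounds shown here, this nitrogen proves less tolerant than the earlier compounds suggested: replacing 3-bromophenyl with 4-chlorophenyl, both halogen-bearing phenyl groups of equal heavy-atom count, gives a 4.5-fold higher number from compound 3 to compound 4 (0.65 log units; beyond the scatter). The comparison with the 3-cyanophenyl group points the same way, with a 2.3-fold higher number from compound 1 to compound 4 (0.35 log units; beyond the scatter), while the comparison with the 2-methylphenyl group gives a 1.7-fold lower number from compound 2 to compound 4 (0.22 log units; within the scatter), which places compound 4 level with compound 2 and apart from compound 1 and compound 3. No supporting measurement bears on why the number moves at this position.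

The halogen and its place on the phenyl ring change together between compound 3 and compound 4, so the compounds shown cannot tell which of the two accounts for the step. Also open, going by these compounds, is how this position would respond to a phenyl ring carrying a methoxy group or an amine.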